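Working notes on a phenylalkanamide series in a cell assay

This account rests on a few compounds, and the source may have more. Where it says the series, first, only, none or still open, it means among the compounds named here.

Measured so far:
compound 1, `O=C(/C=C/CCCCCCc1ccccc1)N1CCCC1`, > 100000 nM
compound 2, `O=C(CCCCCCc1ccccc1)N1CCCCC1`, > 100000 nM
compound 3, `O=C(CCCCCCCCCc1ccccc1)N1CCCCC1`, > 100000 nM

In a functional assay on PANC-1 cells (Homo sapiens) for cytotoxicity, read by WST assay, with a stated time of 24 h (on this read-out higher numbers stand for weaker inhibition and lower numbers for stronger inhibition), compound 1 returns only a limit, not a number. In this assay compound 2 likewise returns only a limit. In this assay compound 3 also returns only a limit. Compound 3 therefore stands at the limit of > 100000 nM in this assay, at which 3 of the 3 values shown sit, and no ordering among the three compounds can be read from these values, since none of them is a number.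

The next compound, compound 4, `O=C(CCCCCCCCc1ccc(F)cc1)N1CCCCC1`, has not been measured in this assay. It differs from compound 3 in one place: 4-fluorophenyl in place of benzyl on a saturated chain carbon, eight bonds along the chain from a carbonyl carbon.

Within the data shown here, no step between measured compounds exists here, so the size of the step is judged only from where compound 3 stands. With compound 3 at the limit, the change from compound 3 to compound 4 is expected to bring no movement beyond the scatter, and compound 4 is expected to sit at the limit as well. For compound 4 an inhibitory concentration of about 150000 nM is estimated, with a range from 50000 nM to 400000 nM. The step that the limit leaves unreadable from compound 3 to compound 4 implied by this estimate is expected to be none beyond the scatter.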

Compound 4, half-maximal inhibitory concentration: 99800 nM
For compound 4 the middle estimate is 1.5-fold (0.18 log units) above the measured one; the range from low to high includes it.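

In this assay, among these compounds, 4-fluorophenyl in place of benzyl at this place on the saturated chain gives the only number so far, and the step reads as a number no higher from compound 3 to compound 4 (the limit leaves the size open). From the compounds shown here alone, the change keeps the heavy-atom count and adds no hydrogen-bond donor or acceptor, yet it shows that this position can be changed with a readable result, although the size of any gain stays unknown. The number still has to be read against the other values, which remain limits: the limit of > 100000 nM in this assay, at which 3 of the 4 values shown sit.

Going by these compounds, it remains open whether the fluorine itself or the altered link between chain and ring accounts for the number, and what an amine or a carboxylic acid would give at this place. A longer chain carrying 4-fluorophenyl also remains untested among the compounds shown here.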